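Replacing a ring amine by a short ether on the shared core

The compounds below may be only part of what the source reports. "The series", "measured", "known", "first", "only" and "open" are said of these compounds alone.

Measured so far:
Compound 1, `CC(C(=O)NCc1ccc(C(C)(C)C)nc1N1CCCCCC1)c1ccc(NS(C)(=O)=O)c(F)c1`: 0.9 nM
Compound 2, `CC(C(=O)NCc1ccc(C(C)(C)C)nc1N1CCC(Cc2ccccc2)CC1)c1ccc(NS(C)(=O)=O)c(F)c1`: 0.3 nM

In an assay on cells for antagonist activity at transient receptor potential cation channel subfamily V member 1 (Homo sapiens), read by FLIPR and calcium flux, with a stated time of 6 min (a lower number here means a stronger inhibitor, a higher number a weaker inhibitor), compound 1 gives 0.9 nM, the higher of the two numbers recorded. Compound 2 gives 0.3 nM in this assay, a difference that lies beyond the usual scatter, so compound 2 is the stronger inhibitor of the pair. Compound 3, `CCCOc1nc(C(C)(C)C)ccc1CNC(=O)C(C)c1ccc(NS(C)(=O)=O)c(F)c1`, has not yet been measured. It differs from compound 1 in one place: propoxy in place of azepan-1-yl on an aromatic carbon. No step between two measured compounds describes this kind of exchange, so the account rests on the two values given above and on the size of the group that leaves against the one that enters. For compound 3 a modest loss of inhibition relative to compound 1 is expected, a step of a 3.3-fold higher number from compound 1 to compound 3 (0.52 log units; beyond the scatter), probably somewhat beyond the scatter. Compound 3 is therefore estimated at 3 nM in this assay, within a range from 0.7 nM to 15 nM.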

Compound 3, inhibition constant: 1.7 nM
Compound 3: middle estimate off by 1.8-fold (0.25 log units), on the high side; the range from low to high includes it.
By their numbers in this assay, from the lowest: compound 2; then compounds 1 and 3 (each within the scatter of the next).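

In this assay, putting propoxy in place of azepan-1-yl on the aromatic carbon next to the ring nitrogen gives a 1.9-fold higher number from compound 1 to compound 3 (0.28 log units; within the scatter). At this position, then, the ring amine of compound 1 is not needed for inhibition at this level: the propoxy group of compound 3, with no ring and fewer heavy atoms, serves about as well. Nothing available explains why the two groups are so closely matched.

For the compounds shown here, the single exchange leaves open whether the ether oxygen itself matters, which a propylamino group or a butyl chain joined directly through carbon could test. It also leaves open how a shorter ethoxy group, a longer butoxy chain or a benzyloxy group would compare with propoxy at this position.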